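Series notes: hydroxybutyl to hydroxyethylcarbamoyl at the five-membered ring

This account rests on a few compounds, and the source may have more. Where it says the series, first, only, none or still open, it means among the compounds named here.

Measured compounds:
Compound 1 `Cc1ccn2c(CCCCO)c(Cn3c(=O)n(C4CC4)c4ccncc43)nc2c1` in an ADME assay on HEp-2 cells (Homo sapiens) for cytotoxicity, read by CCK-8 assay, with a stated time of 6 days (a higher number here means that more compound is tolerated, a lower number that less compound is tolerated), gives > 100000 nM, which is a limit of the assay.
Compound 2 `O=c1n(Cc2nc3cc(F)ccn3c2CCCCO)c2cnccc2n1C1CC1` in this assay gives > 100000 nM, again a limit.
Compound 3 `O=c1n(Cc2nc3cc(Cl)ccn3c2CCCCO)c2cnccc2n1C1CC1` in this assay gives > 100000 nM, also a limit.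

Compound 3 therefore stands only at a limit in this assay, and no number places it relative to the other two; all three values rest on (the limit of > 100000 nM in this assay, at which 3 of the 3 values shown sit).

The three steps among the measured compounds are the halogen or methyl exchanges on the aromatic carbon: a step that the two limits leave unreadable from compound 1 to compound 2, a step that the two limits leave unreadable from compound 1 to compound 3 and a step that the two limits leave unreadable from compound 2 to compound 3. None of them can be read, since both ends of each step are limits.

Compound 4 `O=C(NCCO)c1c(Cn2c(=O)n(C3CC3)c3ccncc32)nc2cc(Cl)ccn12` differs from compound 3 in one place: (2-hydroxyethyl)carbamoyl in place of 4-hydroxybutyl on an aromatic carbon. Going by the values given here, no measured step touches this position or this kind of exchange, so the measured steps give no size and no direction for it. What the measured steps do show is that every change so far has left the value at the limit, and the expectation for compound 4 is the same: an estimated step that the limit leaves unreadable from compound 3 to compound 4, that is none beyond the scatter.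

Compound 4 is thus expected to give about 150000 nM in this assay, with a range from 60000 nM to 400000 nM, and most likely to be reported again only as a limit.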

Compound 4, half-maximal cytotoxic concentration: > 100000 nM
Compound 4: no number, only a limit (the forecaster's own chance of this, stated with the estimate: 85%); the middle value is on the limit's open side.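

No new step can be read: compound 3 and compound 4 both stand only at a limit in this assay, so the exchange of 4-hydroxybutyl for (2-hydroxyethyl)carbamoyl has no readable size: the limit of > 100000 nM in this assay, at which 4 of the 4 values shown sit.

The compounds shown leave open where the half-maximal cytotoxic concentration of each lies, and whether the four differ at all in this assay.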